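The compounds below may be only part of what the source reports. "The series", "measured", "known", "first", "only" and "open" are said of these compounds alone.

Compound 1 `O=C(Nc1cnc(-n2nccn2)c(Cl)c1)Nc1cnc2cc(Cl)nn2c1C1CC1`: < 25 mL.min-1.g-1
Compound 2 `C[C@H]1COC[C@H](C)N1c1c(NC(=O)Nc2ccnc(C(F)(F)F)c2)cnc2cc(Cl)nn12`: 114 mL.min-1.g-1

In an ADME assay on microsomes from liver (Homo sapiens) for metabolic stability (a lower number here means slower removal, a higher number faster removal of the compound), compound 1 gives only a limit, < 25 mL.min-1.g-1, so its true clearance is not pinned to a number. Compound 2 gives 114 mL.min-1.g-1 in this assay. The pair shows the lower reading for compound 1 at the limit of < 25 mL.min-1.g-1 in this assay, at which 1 of the 2 values shown sits. Compound 3 `COCc1c(NC(=O)Nc2cnc(-n3nccn3)c(Cl)c2)cnc2cc(Cl)nn12` is unmeasured; it differs from compound 1 in one place: methoxymethyl in place of cyclopropyl on an aromatic carbon. For the measured compounds named here, no measured step shows what this change does. In this assay compound 3 is expected at 40 mL.min-1.g-1, within 15 mL.min-1.g-1 to 110 mL.min-1.g-1. The expected step is an at least 1.6-fold higher number from compound 1 to compound 3 (0.20 log units; that floor lies within the scatter), a modest rise that could still sit within the scatter.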

Compound 3, intrinsic clearance in microsomes: < 25 mL.min-1.g-1
Compound 3 was reported as a limit (the forecaster's own chance of this, stated with the estimate: 30%); at least 1.6-fold (0.20 log units) between middle value and limit.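

In this assay, for the compounds shown here, compound 1 and compound 3 are both reported only as limits, so no step between them can be read: the limit of < 25 mL.min-1.g-1 in this assay, at which 2 of the 3 values shown sit.

The compounds shown leave open how far each true clearance lies from that limit, and whether methoxymethyl in place of cyclopropyl changes it.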